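A few compounds are considered here, and "the series" means these few. Any claim that something is new, unique, unknown or untested is made for them only; others in the source may bear on it.

Measured so far:
compound 1, `CCN(CC)c1ccc(/C=C/C(=O)c2ccc(OC)c3c2OC(C)(C)C=C3)cc1` — 590 nM
compound 2, `COc1ccc(C(=O)/C=C/c2ccc3ccccc3n2)c2c1C=CC(C)(C)O2` — 4280 nM

In a functional assay on HepG2 cells (Homo sapiens) for antiproliferative activity, read by MTT assay, with a stated time of 24 h (on this read-out lower numbers stand for stronger inhibition and higher numbers for weaker inhibition), compound 1 gives 590 nM, the lowest of the two numbers; compound 2 gives 4280 nM, a higher number well beyond the scatter. The unmeasured compound 3, `COc1ccc(C(=O)/C=C/c2ccc(O)cc2)c2c1C=CC(C)(C)O2`, differs from compound 1 in one place: hydroxy in place of diethylamino on an aromatic carbon, on a six-membered aromatic ring of carbon only, para to a large group. Going by the values given here, no measured pair shows this change, so its size is unknown. Compound 3 is expected to give a moderately higher number than compound 1, a step of a 2.5-fold higher number from compound 1 to compound 3 (0.41 log units; beyond the scatter) in this assay. Compound 3 is estimated at 1500 nM, within a range of 500 nM to 5000 nM.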

Compound 3, half-maximal inhibitory concentration: > 10000 nM
Compound 3: no number, only a limit; the forecaster's own chance of this, stated with the estimate: 5%; at least 6.6-fold (0.82 log units) between middle value and limit.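

This position is far from indifferent to what it carries: putting hydroxy in place of diethylamino on this aromatic carbon, para to a large group, gives an at least 16-fold higher number from compound 1 to compound 3 (1.22 log units; beyond the scatter) in this assay. For compound 3, the value of > 10000 nM is a limit of the assay and not a number. The true size of the step therefore cannot be read: the limit of > 10000 nM in this assay, at which 1 of the 3 values shown sits.

Still open, going by these compounds, is whether a dimethylamino group, a methoxy group or a piperidine ring on the same carbon would keep the number of compound 1. The compounds shown also leave open whether the large step tracks the departure of diethylamino or the arrival of hydroxy.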